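The source may hold more compounds than are shown below. What is called first, only, known or untested is meant among the compounds shown, and "the series" means these compounds.

Compound 1, `Cc1ccnc2nc(-c3cccc(Cl)c3)cc(O)c12`, gives 15.5 nM in a functional assay on PC-3 cells (Homo sapiens) for antiproliferative activity; a lower number here means a stronger inhibitor of growth, a higher number a weaker inhibitor of growth. Compound 3, `Cc1cc(C)c2c(O)cc(-c3cccc(Cl)c3)nc2n1`, differs from compound 1 by methyl in place of hydrogen on an aromatic carbon, and in this assay compound 3 gives 27.5 nM; the step of a 1.8-fold higher number from compound 1 to compound 3 (0.25 log units; within the scatter). Compound 2, `Oc1cc(-c2ccc3ccccc3c2)nc2ncccc12`, is built on a different core, and the difference between the two cores is not broken down here; in this assay compound 2 gives 10500 nM. Compound 4, `Cc1ccnc2nc(-c3ccc4ccccc4c3)cc(O)c12`, differs from compound 2 by methyl in place of hydrogen on an aromatic carbon. This is the same kind of change as that from compound 1 to compound 3, though the places are not the same: in compound 3 the methyl sits next to the ring nitrogen, meta to a methyl group and para to a fused ring, whereas in compound 4 it sits ortho to a fused ring and opposite the ring nitrogen. Because the step of a 1.8-fold higher number from compound 1 to compound 3 (0.25 log units; within the scatter) stayed within the scatter, the step of a 1.2-fold higher number from compound 2 to compound 4 (0.09 log units; within the scatter) is expected to be small as well. For compound 4 in this assay a value of 13000 nM is estimated, between 4500 nM and 40000 nM.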

Compound 4, concentration for 50% growth inhibition: 1380 nM
Compound 4: the middle estimate sits 9.4-fold (0.97 log units) above what was measured; measured number outside the range, below it.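

In this assay, methyl in place of hydrogen on an aromatic carbon gives a 7.6-fold lower number from compound 2 to compound 4 (0.88 log units; beyond the scatter), so the size of this change does not carry over from one core to the other in this series: the same change on two cores in this assay, a 1.8-fold higher number (0.25 log units; within the scatter) from compound 1 to compound 3 and a 7.6-fold lower number (0.88 log units; beyond the scatter) from compound 2 to compound 4, 13-fold (1.13 log units) apart, beyond the scatter of two such steps This shows that a step read on one core is a poor guide to the same change on the other. It does not show what sets the two steps apart, since the cores differ, the methyl sits in different places and compound 3 already carries another methyl, while only two pairs are shown.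

The compounds shown leave open whether an ethyl group, a methoxy group or an amine on the aromatic carbon opposite the ring nitrogen would follow methyl. They also leave open how such a group would behave on either core.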